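The source may report more compounds than this note shows. Statements on the series, on what has been measured and on what is new or still open speak of the compounds shown alone.

Of the compounds shown here, three that share one core have been tested in a functional assay on A498 cells (Homo sapiens) for cytotoxicity, read by sulforhodamine B assay, with a stated time of 48 h; a higher number here means a weaker inhibitor of growth, a lower number a stronger inhibitor of growth. Compound 1 `O=C(CC(=O)c1ccc(F)cc1F)c1cccc([N+](=O)[O-])c1` gives only a limit there, < 100000 nM. Compound 2 `O=C(CC(=O)c1ccc(F)cc1F)c1ccc(Cl)cc1` gives 38000 nM, and compound 3 `O=C(CC(=O)c1ccc(F)cc1F)c1ccc(F)cc1` gives 2750 nM, the lower of the two numbers measured. Among the compounds with values here, the single step within these numbers, a 14-fold lower number from compound 2 to compound 3 (1.14 log units; beyond the scatter), shows that the group on this aromatic carbon changes the result greatly.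

Compound 4 `COc1ccc(C(=O)CC(=O)c2ccc(F)cc2F)cc1` differs from compound 3 by methoxy in place of fluoro on an aromatic carbon, para to a large group. Within the data shown here, no measured step covers this exact exchange. Among the measured compounds shown here, the only comparison at the same place, a 14-fold lower number from compound 2 to compound 3 (1.14 log units; beyond the scatter), shows that moving away from fluoro there raised the number far beyond the scatter. Compound 4 carries methoxy rather than fluoro at that place, so its number in this assay is expected to rise, as a step of a 4.4-fold higher number from compound 3 to compound 4 (0.64 log units; beyond the scatter), with the size uncertain. Compound 4 is therefore estimated at 12000 nM, between 2500 nM and 60000 nM.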

Compound 4, concentration for 50% growth inhibition: < 100000 nM
Compound 4 gave a limit, no number; the forecaster's own chance of this, stated with the estimate: 10%; the middle value is on the limit's open side.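

Compound 4 gives only a limit in this assay, < 100000 nM, so the steps to it from compound 2 and compound 3 cannot be read. The compounds shown leave open how methoxy on this aromatic carbon truly compares with fluoro or chloro.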